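Extending the amine chain: from compound 1 toward compound 4

A few compounds are considered here, and "the series" means these few. Any claim that something is new, unique, unknown or untested is made for them only; others in the source may bear on it.

Of the compounds shown here, three of a shared core have been tested in a functional assay on HepG2 cells (Homo sapiens) for cytotoxicity, read by MTT assay, with a stated time of 48 h; a lower number here means a stronger inhibitor, a higher number a weaker inhibitor. Compound 1, with structure `COc1cc(/C=C/C(=O)/C=C(/C=C/c2ccc(O)c(OC)c2)NCCO)ccc1O`, gives only a limit of the assay in this assay, reported as > 100000 nM. For the measured compounds named here, that limit, (the limit of > 100000 nM in this assay, at which 1 of the 3 values shown sits), is the highest value among the three and is the only one at which no number could be given. Compound 2, `COCCCNC(=C\C(=O)/C=C/c1ccc(O)cc1)/C=C/c1ccc(O)cc1`, gives 61900 nM in this assay. Compound 3, `O=C(/C=C(/C=C/c1ccc(O)cc1)NCCCO)/C=C/c1ccc(O)cc1`, gives 54100 nM in this assay. Going by the values given here, the one step between measured compounds that differ in a single place, a 1.1-fold lower number from compound 2 to compound 3 (0.06 log units; within the scatter), concerns hydrogen in place of methyl on an oxygen on a saturated carbon and lies within the scatter.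

Compound 4, with structure `COCCCNC(=C\C(=O)/C=C/c1ccc(O)c(OC)c1)/C=C/c1ccc(O)c(OC)c1`, is not yet measured. It differs from compound 1 in one place: methoxymethyl in place of hydroxy on a saturated chain carbon, two bonds along the chain from an amine nitrogen. The step from compound 2 to compound 3 is the closest measured analogue, as it also swaps a methyl for a hydrogen on a chain oxygen, and it produced no change beyond the scatter. On that basis no step beyond the scatter is expected in this assay, so compound 4 is estimated to stand near the limit of compound 1, at 100000 nM with a range of 50000 nM to 200000 nM. The expected step is a number no higher from compound 1 to compound 4 (the limit leaves the size open).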

Compound 4, half-maximal inhibitory concentration: > 100000 nM
Compound 4: a limit, no number; the forecaster's own chance of this, stated with the estimate: 60%; the middle value sits exactly at the limit.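

In this assay, for the compounds shown here, compound 4 gives a limit of the assay and not a number, as compound 1 does, so no step between compound 1 and compound 4 can be read: the limit of > 100000 nM in this assay, at which 2 of the 4 values shown sit. The compounds shown leave open where either compound truly stands, and whether methoxymethyl in place of hydroxy changes the number at all.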